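This account rests on a few compounds, and the source may have more. Where it says the series, first, only, none or still open, it means among the compounds named here.

Compound 1 `Nc1ccc(S(=O)(=O)N2CCN(c3ncc(C(O)(C(F)(F)F)C(F)(F)F)cc3C3CC3)CC2)cn1`: 38 mL.min-1.g-1
Compound 2 `NC(=O)c1cccc(-c2cc(C(O)(C(F)(F)F)C(F)(F)F)cnc2N2CCN(S(=O)(=O)c3ccc(N)nc3)CC2)c1`: 17 mL.min-1.g-1

In an ADME assay (liver) for metabolic stability, with Liver microsome (Homo sapiens) as the target, using microsomes and NADPH, with a stated time of 30 min, tested at 1 uM (a lower number here means slower removal, a higher number faster removal of the compound), compound 2 has the lower of the two numbers, at 17 mL.min-1.g-1. Compound 3 `Nc1ccc(S(=O)(=O)N2CCN(c3ncc(C(O)(C(F)(F)F)C(F)(F)F)cc3-c3cnccc3F)CC2)cn1` carries the next change at the same place: 4-fluoropyridin-3-yl in place of 3-carbamoylphenyl on an aromatic carbon. For the measured compounds named here, only one measured step bears on this place, the modest 2.2-fold lower number from compound 1 to compound 2 (0.35 log units; beyond the scatter). Going by the values given here, no compound with a 4-fluoropyridin-3-yl group has been measured, so that step gives only a rough guide. No change beyond the scatter is expected, with a slight upward lean, and the estimated step is a 1.3-fold higher number from compound 2 to compound 3 (0.11 log units; within the scatter). Compound 3 is expected at 22 mL.min-1.g-1, with an estimated range of 11 mL.min-1.g-1 to 42 mL.min-1.g-1.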

Compound 3, intrinsic clearance in microsomes: 17 mL.min-1.g-1
Beside the measured number, compound 3's estimate is 1.3-fold (0.11 log units) above it, within the range that was stated.
By their numbers in this assay, from the lowest: compounds 2 and 3 (each within the scatter of the next); then compound 1.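

In this assay, 4-fluoropyridin-3-yl in place of 3-carbamoylphenyl on this aromatic carbon gives no change at the digits printed from compound 2 to compound 3 (within the scatter), so these two aromatic groups cannot be told apart here despite their different ring atoms and hydrogen-bond donors. Against cyclopropyl, 4-fluoropyridin-3-yl gives a 2.2-fold lower number from compound 1 to compound 3 (0.35 log units; beyond the scatter), so the lower number is no longer tied to 3-carbamoylphenyl alone. No measured evidence accounts for these steps. Open, on these data alone, is whether an unsubstituted phenyl ring, an aliphatic amine or a carboxylic acid at this position would read with the two aromatic groups or with cyclopropyl.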